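Extending the chalcone of compound 2 with an allyloxybenzyl group

The source may report more compounds than this note shows. Statements on the series, on what has been measured and on what is new or still open speak of the compounds shown alone.

Going by the values given here, compound 1 `COc1cc(OC)c(C(C)=O)c(OC)c1` and compound 2 `COc1cc(OC)c(C(=O)/C=C/c2ccccc2)c(OC)c1` are the two measured members. In a functional assay on U-937 cells (Homo sapiens) for cytotoxicity, read by resazurin assay, with a stated time of 72 h (a higher number here means a weaker inhibitor, a lower number a stronger inhibitor), compound 1 gives 7200 nM, and in this assay compound 2 gives 6700 nM. Compound 2 has the lower of the two numbers, but the gap to compound 1 lies within the scatter, so no order between them can be claimed.

Compound 3 `C=CCOc1ccccc1Cc1c(OC)cc(OC)c(C(=O)/C=C/c2ccccc2)c1OC` is not yet measured. Relative to compound 2 the change is 2-(allyloxy)benzyl in place of hydrogen on an aromatic carbon. Among the compounds with values here, no measured pair shows a step of this kind, so the size of the step in this assay is open. The expectation is a modest gain for compound 3, of a size that may or may not exceed the scatter, and the estimated step of a 2.2-fold lower number from compound 2 to compound 3 (0.35 log units; beyond the scatter) reflects this. Compound 3 is accordingly expected to give about 3000 nM in this assay, with a range from 800 nM to 12000 nM.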

Compound 3, half-maximal inhibitory concentration: 7500 nM
The estimate for compound 3 lay 2.5-fold (0.40 log units) below the measured number; low and high end bracket the measured number.
By their numbers in this assay, from the lowest: compounds 2, 1 and 3 (each within the scatter of the next).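

In this assay, going by these compounds alone, the step at the aromatic carbon ortho to two methoxy groups, 2-(allyloxy)benzyl in place of hydrogen, is a 1.1-fold higher number from compound 2 to compound 3 (0.05 log units; within the scatter) and is the only step that can be read. This position therefore accepts a substituent with a further six-membered aromatic ring while the number stays within the scatter of compound 2. On this single pair, the added 2-(allyloxy)benzyl group brings no measurable gain in this read-out. No supporting data bear on why the step is so small.

Still open, on these data alone, is whether an amine or a carboxylic acid on the added benzyl ring would give a step beyond the scatter. A plain methyl or a longer chain at this position also remains to be compared with 2-(allyloxy)benzyl.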